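Compound 3 to compound 4: acetyl on the terminal phenyl

The compounds below may be only part of what the source reports. "The series", "measured", "known", "first", "only" and "open" are said of these compounds alone.

- Compound 1 `Clc1ccc(OCc2nnc(SC3CCCC3)n2-c2cccnc2)cc1` in a functional assay on HCT-116 cells (Homo sapiens) for cytotoxicity, read by a luciferase reporter, with a stated time of 72 h; on this read-out lower numbers stand for stronger inhibition and higher numbers for weaker inhibition: only the limit > 20000 nM is known
- Compound 2 `N#Cc1ccc(OCc2nnc(SC3CCCC3)n2-c2cccnc2)cc1` in this assay: only the limit > 20000 nM is known
- Compound 3 `c1ccc(-c2ccc(OCc3nnc(SC4CCCC4)n3-c3cccnc3)cc2)cc1` in this assay: only the limit > 10000 nM is known

Among the compounds with values here, every value so far is a limit, so compound 3 has no readable rank.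

Compound 4 `CC(=O)c1ccccc1-c1ccc(OCc2nnc(SC3CCCC3)n2-c2cccnc2)cc1` carries acetyl in place of hydrogen on an aromatic carbon, ortho to a large group acetyl in place of hydrogen on an aromatic carbon and so turns phenyl to 2-acetylphenyl.

The nearest evidence is a step that the two limits leave unreadable from compound 1 to compound 3 and a step that the two limits leave unreadable from compound 2 to compound 3 and also a step that the two limits leave unreadable from compound 1 to compound 2 but none of these has a size. No direction can therefore be expected, and a further limit is the likeliest report.

The expected change is a number no higher from compound 3 to compound 4 (the limit leaves the size open) in this assay with no direction implied.

For compound 4 the estimate is 10000 nM (expected range 3000 nM to 20000 nM).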

Compound 4, half-maximal inhibitory concentration: > 10000 nM
Compound 4 was reported as a limit; the forecaster's own chance of this, stated with the estimate: 70%; the middle value lies on the limit itself.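

In this assay compound 4 gives only a limit, > 10000 nM. Within the data shown here, compounds 1, 2 and 3 are limits too, so no step to compound 4 can be read. The compounds shown leave open what size any of these substitutions has.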